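The source may report more compounds than this note shows. Statements on the series, on what has been measured and on what is new or still open speak of the compounds shown alone.

Compound 1 `Cc1ccc(Nc2nccc(-c3c(C)nc4ccccn34)n2)cc1` holds the lower of the two numbers recorded so far. In a functional assay on MCF7 cells (Homo sapiens) for cytotoxicity, read by sulforhodamine B assay, with a stated time of 48 h (a higher number here means a weaker inhibitor, a lower number a stronger inhibitor), compound 1 gives 59 nM, while compound 2 `Nc1nccc(-c2ccnc3ccccc23)n1` gives 40300 nM, a gap that lies far beyond the scatter. Compound 3 `Cc1nc2ccccn2c1-c1ccnc(Nc2ccc(C=O)s2)n1` differs from compound 1 in a single place: 5-formylthiophen-2-yl in place of 4-methylphenyl on a nitrogen on an aromatic ring. For the measured compounds named here, no measured pair shows this change, so the size of the step is open. A modest move toward a higher number is expected, written as a 2.5-fold higher number from compound 1 to compound 3 (0.41 log units; beyond the scatter). For compound 3 the expected value in this assay is 150 nM, with a range from 30 nM to 800 nM.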

Compound 3, half-maximal inhibitory concentration: 4270 nM
For compound 3 the middle estimate is 28-fold (1.45 log units) below the measured one; the whole stated range lies below it.
By their numbers in this assay, from the lowest: compound 1; then compound 3; then compound 2.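

On the nitrogen on an aromatic ring, replacing 4-methylphenyl with 5-formylthiophen-2-yl gives a large change in this assay: a 72-fold higher number from compound 1 to compound 3 (1.86 log units; beyond the scatter). This position is therefore sensitive to the group it carries, even though the two groups hold the same number of heavy atoms. Nothing available explains the size of this step.

The compounds shown do not separate the change of ring from the change of substituent, since the thiophene ring and the formyl group enter together. A formylphenyl or a methylthiophenyl group on the same nitrogen would change only one of the two.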